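Nitro to Amino: an Expected Gain on the Second Core

A few compounds are considered here, and "the series" means these few. Any claim that something is new, unique, unknown or untested is made for them only; others in the source may bear on it.

Compound 1 `COc1ccc(-c2ssc(=S)c2-c2cc(OC)c(OC)c(OC)c2)cc1[N+](=O)[O-]` and compound 2 `COc1ccc(-c2ssc(=S)c2-c2cc(OC)c(OC)c(OC)c2)cc1N` share one core, while compound 3 `CO/N=c1/ssc(-c2cc(OC)c(OC)c(OC)c2)c1-c1ccc(OC)c([N+](=O)[O-])c1` and compound 4 `CO/N=c1/ssc(-c2cc(OC)c(OC)c(OC)c2)c1-c1ccc(OC)c(N)c1` share another; the difference between the two cores is not broken down here. In a functional assay on KB cells (Homo sapiens) for antiproliferative activity, read by MTT assay, with a stated time of 72 h (on this read-out lower numbers stand for stronger inhibition and higher numbers for weaker inhibition), compound 1 gives only a limit, > 100000 nM. Compound 2 gives 327 nM in this assay. The step of an at least 300-fold lower number from compound 1 to compound 2 (2.48 log units; beyond the scatter) rests on one change, (amino in place of nitro on an aromatic carbon), and its size can only be given as a floor because the limit of > 100000 nM in this assay, at which 2 of the 3 values shown sit, caps what compound 1 could show. Compound 3 gives only a limit in this assay, > 100000 nM. Compound 4 differs from compound 3 by the same change, (amino in place of nitro on an aromatic carbon), made at a place described in the same words as for compound 2. The step from compound 3 to compound 4 is therefore expected to be large, an at least 120-fold lower number from compound 3 to compound 4 (2.09 log units; beyond the scatter), on the strength of compound 2 and its value 327 nM in this assay. Compound 4 is expected to give about 800 nM in this assay, most likely between 150 nM and 20000 nM.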

Compound 4, half-maximal inhibitory concentration: 517 nM
For compound 4 the middle estimate is 1.5-fold (0.19 log units) above the measured one; low and high end bracket the measured number.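

On the second core, amino in place of nitro on an aromatic carbon brings an at least 190-fold lower number from compound 3 to compound 4 (2.28 log units; beyond the scatter) in this assay and so gives a large step, as it did on the first core. The change therefore carries over between these two cores in direction and as a large step, and the comparison reads: the same change on two cores in this assay, an at least 300-fold lower number (2.48 log units; beyond the scatter) from compound 1 to compound 2 and an at least 190-fold lower number (2.28 log units; beyond the scatter) from compound 3 to compound 4; the limit leaves it open whether they differ. This does not give the true size of either step or show that the change would behave alike on any further core, and both steps remain floors because each starts from a limit: the limit of > 100000 nM in this assay, at which 2 of the 4 values shown sit.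

The compounds shown leave open whether other groups in the same place, such as a hydroxyl, an acetamide or a dimethylamino group, would match amino on these cores. They also leave open what amino would do elsewhere on this six-membered ring, or on the ring carrying the three methoxy groups.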